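The source may hold more compounds than are shown below. What is called first, only, known or untested is meant among the compounds shown, and "the series" means these compounds.

Measured compounds in an assay on isolated protein for antagonist activity at Bile acid receptor (Homo sapiens), read by HTRF, with a stated time of 30 min; a lower number here means a stronger inhibitor, a higher number a weaker inhibitor:
Compound 1 `CC(C)(C)c1cc(OC(=O)c2ccc([N+](=O)[O-])cc2Cl)ccc1O` gives 8800 nM.
Compound 2 `CC(C)(C)c1cc(NC(=O)c2ccc(Cl)cc2Cl)ccc1O` gives 13600 nM.
Compound 3 `CC(C)(C)c1cc(NC(=O)c2ccc(Cl)cc2Cl)cc(C(C)(C)C)c1O` gives > 100000 nM, which is a limit of the assay, not a number.

Compound 2 and compound 1 lie within the usual scatter of each other; compound 3 sits at the limit (the limit of > 100000 nM in this assay, at which 1 of the 3 values shown sits). The change to compound 4 `CCc1cc(NC(=O)c2ccc(Cl)cc2Cl)ccc1O` is ethyl in place of tert-butyl on an aromatic carbon. Going by the values given here, the only measured step at that position is an at least 7.3-fold higher number from compound 2 to compound 3 (0.86 log units; beyond the scatter), where added bulk at the site ortho to the hydroxy group cost potency. Trimming tert-butyl to ethyl is the opposite direction but a different change, so the expected step is small. Compound 4 is expected at 12000 nM (range 4000 nM to 40000 nM). The expected step is a 1.1-fold lower number from compound 2 to compound 4 (0.05 log units; within the scatter), within the scatter.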

Compound 4, half-maximal inhibitory concentration: > 100000 nM
Compound 4 gave a limit, no number (the forecaster's own chance of this, stated with the estimate: 10%); at least 8.3-fold (0.92 log units) between middle value and limit.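

In this assay, the result shows that this position does not accept a shorter group: ethyl in place of tert-butyl, ortho to a hydroxy group, gives an at least 7.3-fold higher number from compound 2 to compound 4 (0.86 log units; beyond the scatter). Potency at this position therefore depends on the tert-butyl itself, which compound 3 could not show, since there a tert-butyl was added and nothing was removed. Neither step has a known full size, as each ends at a limit of the assay: the limit of > 100000 nM in this assay, at which 2 of the 4 values shown sit.

Open, going by these compounds, is whether isopropyl or cyclopropyl at this position keeps a value near that of compound 2, 13600 nM. The ethyl result also says nothing about methyl or a longer chain.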